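Swapping a phosphate prodrug group for an acetoxybenzoyl ester

A few compounds are considered here, and "the series" means these few. Any claim that something is new, unique, unknown or untested is made for them only; others in the source may bear on it.

Compound 3 `CCOP(=O)(OCC)OCN1C(=O)N[C@@](CN2Cc3ccc(OC)cc3C2=O)(c2cc3ncccc3o2)C1=O` gives the lowest exposure of the three compounds in an ADME assay on the whole organism for pharmacokinetics, with Rattus norvegicus as the target, read by LC-MS, at a dose of 10 mg/kg by the oral route (a lower number here means less compound in the circulation, a higher number more compound in the circulation at the dose given), with 27.9 ng.h/mL. Compound 1 `COc1ccc2c(c1)C(=O)N(C[C@@]1(c3cc4ncccc4o3)NC(=O)N(COC(=O)C(C)(C)C)C1=O)C2` gives 6640 ng.h/mL and compound 2 `COc1ccc2c(c1)C(=O)N(C[C@@]1(c3cc4ncccc4o3)NC(=O)N(C(C)C)C1=O)C2` gives 174 ng.h/mL. Compound 4 `COc1ccc2c(c1)C(=O)N(C[C@@]1(c3cc4ncccc4o3)NC(=O)N(COC(=O)c3ccccc3OC(C)=O)C1=O)C2` differs from compound 3 by a group of 12 heavy atoms (9 carbon, 3 oxygen; one six-membered aromatic ring of carbon only) in place of a group of 8 heavy atoms (4 carbon, 3 oxygen, 1 phosphorus; no ring), on an oxygen on a saturated carbon. The most relevant comparison is the step from compound 1 to compound 3, a 240-fold lower number from compound 1 to compound 3 (2.38 log units; beyond the scatter), where a carbon-based acyl ester on the same oxygen was replaced by the phosphorus-containing group; compound 4 returns to a carbon-based acyl ester, so the change is expected to run in the opposite direction, with a large rise in circulating compound. Compound 4 is therefore expected to give about 2000 ng.h/mL, within 400 ng.h/mL to 8000 ng.h/mL, an expected step of a 72-fold higher number from compound 3 to compound 4 (1.86 log units; beyond the scatter).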

Compound 4, area under the concentration-time curve: 2570 ng.h/mL
The estimate for compound 4 lay 1.3-fold (0.11 log units) below the measured number; measured number inside the range.
By their numbers in this assay, from the lowest: compound 3; then compound 2; then compound 4; then compound 1.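

In this assay, among these compounds, the (2-acetoxyphenyl)carbonyl group on this oxygen brings a 92-fold higher number from compound 3 to compound 4 (1.96 log units; beyond the scatter) and shows that a second carbon-based acyl group, not only the one in compound 1, gives a high number here. The acyl group still matters, since 2-acetoxyphenyl in place of tert-butyl on the carbonyl carbon brings a 2.6-fold lower number from compound 1 to compound 4 (0.41 log units; beyond the scatter) and does not fully match the earlier ester. No measurement shown explains either step. On these data alone, whether a plain phenyl or a longer chain on that carbonyl carbon would land nearer compound 1 or compound 4 remains open.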